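A few compounds are considered here, and "the series" means these few. Any claim that something is new, unique, unknown or untested is made for them only; others in the source may bear on it.

Going by the values given here, only two compounds have numbers so far. In a functional assay on HL-60 cells (Homo sapiens) for antiproliferative activity (a lower number here means a stronger inhibitor, a higher number a weaker inhibitor), compound 1 (`COc1cc(/C=C/c2cccc(OC)c2O)cc(OC)c1`) gives 3500 nM, and compound 2 (`COc1cc(OC)cc(-c2ccc(-c3ccc(O)cc3)cc2)c1`) gives 2500 nM. These two values lie within the usual scatter of repeated measurements, so compound 2 stands level with compound 1 and the two cannot be ranked.

Compound 3 (`COc1ccc(-c2ccc(-c3cc(OC)cc(OC)c3)cc2)cc1`) has not yet been measured. It differs from compound 2 in one place: methyl in place of hydrogen on an oxygen on an aromatic ring. This is a methyl in place of hydrogen on an oxygen on an aromatic ring, so 4-hydroxyphenyl becomes 4-methoxyphenyl.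

Among the compounds with values here, the measured compounds include no pair that differs in one place, so no measured step can serve as a guide for this change. Any expectation is therefore loose. In this assay, a small step toward a somewhat higher number is expected, and a result within the scatter of compound 2 would be no surprise. The expected change is a 1.6-fold higher number from compound 2 to compound 3 (0.20 log units; within the scatter). The estimate for compound 3 is 4000 nM, with a likely range from 1200 nM to 13000 nM.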

Compound 3, half-maximal inhibitory concentration: 75000 nM
Compound 3: the middle estimate sits 19-fold (1.27 log units) below what was measured; measured number outside the range, above it.
By their numbers in this assay, from the lowest: compounds 2 and 1 (each within the scatter of the next); then compound 3.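

Replacing the hydrogen of the hydroxy group with methyl, which turns 4-hydroxyphenyl into 4-methoxyphenyl, gives a 30-fold higher number from compound 2 to compound 3 (1.48 log units; beyond the scatter) in this assay and counts as a large change. Going by these compounds alone, this is the first comparison here between two compounds that differ in only one place, and it shows that this oxygen on an aromatic ring is a sensitive position. A single added carbon is enough to separate compound 2, which stands level with compound 1, from the clearly weaker compound 3, so at this position a hydroxy and a methoxy cannot be treated as interchangeable.

Nothing measured here explains why the number climbs so far. From the compounds shown here alone, it remains open whether the loss comes from removing the hydrogen or from adding the methyl, and whether a different group on this oxygen, such as ethyl or a longer chain, or an amine or a carboxylic acid in place of the hydroxy, would keep the activity of compound 2 or lose it as well.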